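Cyclopropylmethyl in place of butyl on a pyridone nitrogen

A few compounds are considered here, and "the series" means these few. Any claim that something is new, unique, unknown or untested is made for them only; others in the source may bear on it.

Compound 1 `CC(C)CCn1ccc(N(C)Cc2ccccc2)c(C#N)c1=O` gives 10700 nM in a functional assay on CHO cells for positive allosteric modulation of metabotropic glutamate receptor 2 (Homo sapiens), with a stated time of 30 min; on this read-out lower numbers stand for an effect already at smaller amounts and higher numbers for an effect only at larger amounts of compound. Compound 2 `CC(C)CCn1ccc(N2CCN(c3ccccc3)CC2)c(C#N)c1=O` gives 661 nM. Compound 3 `CCCCn1ccc(N2CCC(c3ccccc3)CC2)c(C#N)c1=O` gives 95 nM.

Of the three measured compounds, compound 3 stands at the lowest number in this assay, and its distances to compound 2 and to compound 1 both lie beyond the usual scatter, so within this small set compound 3 is the most potent. Compound 4 `N#Cc1c(N2CCC(c3ccccc3)CC2)ccn(CC2CC2)c1=O` has not yet been measured; it differs from compound 3 only at the group on the aromatic nitrogen: cyclopropyl in place of propyl on a saturated chain carbon bound to an aromatic nitrogen, which amounts to cyclopropylmethyl in place of butyl.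

Among the measured compounds shown here, no pair of measured compounds differing at this position is available, so the size of this step cannot be read from the data. The chain length and the group at the other end of the core are unchanged between compound 3 and compound 4. The step from compound 3 to compound 4 is therefore expected to be small, a 1.1-fold lower number from compound 3 to compound 4 (0.02 log units; within the scatter), and not clearly beyond the scatter. Compound 4 is estimated to give 90 nM in this assay, with a likely range from 30 nM to 300 nM.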

Compound 4, half-maximal effective concentration: 151 nM
The estimate for compound 4 lay 1.7-fold (0.22 log units) below the measured number; low and high end bracket the measured number.
By their numbers in this assay, from the lowest: compounds 3 and 4 (each within the scatter of the next); then compound 2; then compound 1.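

Going from butyl to cyclopropylmethyl as the group bound to the aromatic nitrogen, this assay shows a 1.6-fold higher number from compound 3 to compound 4 (0.20 log units; within the scatter). Among the compounds shown here, this is the first pair among the compounds that differs at this place alone, and it shows that closing a three-membered ring of carbon in this group, with the same count of heavy atoms leaving and entering, gives no change that can be told from the scatter. Nothing available here offers an explanation for this result.

From the compounds shown here alone, whether a longer chain such as hexyl, or a cyclobutylmethyl or benzyl group, at this place would move the number beyond the scatter remains open. Going by these compounds, it is also open whether the same exchange would give a step of similar size with the other groups of compound 2 on the shared core.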